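Series notes: methoxy removal on the acetoxy-bearing aryl ring

A few compounds are considered here, and "the series" means these few. Any claim that something is new, unique, unknown or untested is made for them only; others in the source may bear on it.

Measured compounds in an assay on membranes from brain for displacement of a labelled ligand from Neuronal acetylcholine receptor; alpha4/beta2 (Rattus norvegicus), with a stated time of 3 h; on this read-out lower numbers stand for stronger inhibition and higher numbers for weaker inhibition:
compound 1 `CC(C)(C)C(=O)Oc1ccccc1/C=C1\CCCN=C1c1cccnc1`: 1440 nM
compound 2 `C(=C1\CCCN=C1c1cccnc1)\c1ccccc1`: 850 nM
compound 3 `COc1ccc(/C=C2\CCCN=C2c2cccnc2)c(OC(C)=O)c1`: 770 nM

On these three numbers compound 3 sits at the low end, but its gap to compound 2 and its gap to compound 1 are both within the scatter of this assay, so none of the three is separated from the others.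

Compound 4 `CC(=O)Oc1ccccc1/C=C1\CCCN=C1c1cccnc1` is compound 3 with the change (hydrogen in place of methoxy on an aromatic carbon). Among the compounds with values here, no measured pair removes a methoxy. Within the data shown here, the only step with a bearing on it is the loss of a substituent from the same aryl ring, a 1.7-fold lower number from compound 1 to compound 2 (0.23 log units; within the scatter), which removed a far larger group than methoxy and still stayed within the scatter. The shared core carries the pyridyl and the ring-fused amidine portion unchanged in compounds 1 to 3, and all three numbers lie close together whatever the aryl ring carries. A small change on that ring is therefore expected to leave the number within the scatter of compound 3.

For compound 4 the estimate in this assay is 800 nM, with a range of 350 nM to 1800 nM, corresponding to an expected step of a 1.0-fold higher number from compound 3 to compound 4 (0.02 log units; within the scatter).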

Compound 4, inhibition constant: 700 nM
Beside the measured number, compound 4's estimate is 1.1-fold (0.06 log units) above it; measured number inside the range.
By their numbers in this assay, from the lowest: compounds 4, 3, 2 and 1 (each within the scatter of the next, the first and the last beyond it).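

In this assay, the aromatic carbon meta to an acetoxy group and para to a large group gives its first direct reading for this change: hydrogen in place of methoxy leaves the number within the scatter (a 1.1-fold lower number from compound 3 to compound 4 (0.04 log units; within the scatter)), so the methoxy group can go without a separable shift. The acetoxy group alone is likewise not separated from the unsubstituted ring (a 1.2-fold lower number from compound 2 to compound 4 (0.08 log units; within the scatter)). Methyl in place of tert-butyl on the carbonyl carbon gives the first one-place step in these compounds to lie beyond the scatter, though only modestly (a 2.1-fold lower number from compound 1 to compound 4 (0.31 log units; beyond the scatter)), so the one separation seen here sits at the acyl end of the ester and not at the methoxy position.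

On these data alone, whether an amine, a carboxylic acid or a longer chain such as butoxy on this aromatic carbon would move the number beyond the scatter remains open, as does the effect of a free hydroxyl in place of the acetoxy group. No measurement beyond these binding numbers is available to account for any of these steps.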